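The source may report more compounds than this note shows. Statements on the series, on what has been measured and on what is new or still open speak of the compounds shown alone.

In a functional assay on HeLa cells (Homo sapiens) for inhibition, read by sulforhodamine B assay (a lower number here means a stronger inhibitor, a higher number a weaker inhibitor), compound 3 `O=C1C(N2CCC2)=CC(=O)c2c1nc1n2[C@H]2OC[C@@H](O)[C@H]2OC1` reads > 16000 nM, which is a limit of the assay and not a number. Compound 4 `O=C1C(NCc2ccccc2)=CC(=O)c2c1nc1n2[C@H]2OC[C@@H](O)[C@H]2OC1` differs from it by benzylamino in place of azetidin-1-yl on a double-bonded ring carbon. The bearing data come from compound 1 `COc1ccccc1NC1=CC(=O)c2c(nc3n2[C@H]2OC[C@@H](O)[C@H]2OC3)C1=O` at 7460 nM and compound 2 `O=C1C(Nc2ccc(C(F)(F)F)cc2)=CC(=O)c2c1nc1n2[C@H]2OC[C@@H](O)[C@H]2OC1` at 8920 nM. Azetidin-1-yl in place of (2-methoxyphenyl)amino gave an at least 2.1-fold higher number from compound 1 to compound 3 (0.33 log units; beyond the scatter), whereas 4-(trifluoromethyl)phenyl in place of 2-methoxyphenyl gave a 1.2-fold higher number from compound 1 to compound 2 (0.08 log units; within the scatter). Benzylamino itself has not been measured, so the transfer from these steps is uncertain. A modest move toward a lower number in this assay is expected, and the estimated step is an at least 1.7-fold lower number from compound 3 to compound 4 (0.24 log units; that floor lies within the scatter). Compound 4 is estimated at 9000 nM, with an expected range of 4000 nM to 18000 nM.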

Compound 4, half-maximal inhibitory concentration: 11000 nM
Compound 4: the middle estimate sits 1.2-fold (0.09 log units) below what was measured; the measured number falls inside the stated range.
By their numbers in this assay, from the lowest: compounds 1, 2 and 4 (each within the scatter of the next). At a limit, above all of these: compound 3.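

In this assay, benzyl on this amine nitrogen reads alike with the two aryl groups: a 1.2-fold higher number from compound 2 to compound 4 (0.09 log units; within the scatter) and a 1.5-fold higher number from compound 1 to compound 4 (0.17 log units; within the scatter). The step away from the four-membered ring is an at least 1.4-fold lower number from compound 3 to compound 4 (0.16 log units; that floor lies within the scatter), so benzylamino is not separated from azetidin-1-yl at this double-bonded ring carbon. Compound 3 still stands at a limit and not a number: the limit of > 16000 nM in this assay, at which 1 of the 4 values shown sits.

From the compounds shown here alone, what a phenethylamino or a plain alkylamino group would read at this carbon stays open. So does whether a larger ring such as morpholin-4-yl, also without the amine hydrogen, would read at the same limit.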